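This account rests on a few compounds, and the source may have more. Where it says the series, first, only, none or still open, it means among the compounds named here.

Among the measured compounds shown here, in a functional assay on HCT-116 cells (Homo sapiens) for antiproliferative activity, read by MTT assay, with a stated time of 72 h (on this read-out higher numbers stand for weaker inhibition and lower numbers for stronger inhibition), compound 1 (`O=C(Nc1ccc(Nc2nccc(NC3CCCC3)n2)cc1)Nc1ccc(Cl)c(C(F)(F)F)c1`) gives 2510 nM, the only actual number so far. Compound 2 (`O=C(Nc1ccc(Nc2nccc(Nc3ccccc3)n2)cc1)Nc1ccc(Cl)c(C(F)(F)F)c1`) reads > 50000 nM, which is a limit of the assay and not a number. For the measured compounds named here, the one measured step is an at least 19-fold higher number from compound 1 to compound 2 (1.29 log units; beyond the scatter), with phenyl in place of cyclopentyl on a nitrogen on an aromatic ring.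

Compound 3 (`O=C(Nc1ccc(Nc2nccc(NC3CCCC3)n2)cc1)Nc1cccc(C(F)(F)F)c1`) keeps the cyclopentyl of compound 1 and changes another place: hydrogen in place of chloro on an aromatic carbon. This is hydrogen in place of chloro on an aromatic carbon, ortho to a trifluoromethyl group, so that 4-chloro-3-(trifluoromethyl)phenyl becomes 3-(trifluoromethyl)phenyl. The measured step is large but lies elsewhere in the molecule, so it bears only indirectly, as a sign that a single change can matter in this series. Going by the values given here, no measured step covers the chloro position. In this assay, among the compounds with values here, no step clearly beyond the scatter is therefore expected, with a lean toward a higher number. The expected outcome is a 1.6-fold higher number from compound 1 to compound 3 (0.20 log units; within the scatter). Compound 3 is estimated at 4000 nM, with an expected range of 1300 nM to 13000 nM.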

Compound 3, half-maximal inhibitory concentration: 2410 nM
Compound 3: middle estimate off by 1.7-fold (0.22 log units), on the high side, and the stated range covers the measured number.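

In this assay, going from 4-chloro-3-(trifluoromethyl)phenyl to 3-(trifluoromethyl)phenyl gives a 1.0-fold lower number from compound 1 to compound 3 (0.02 log units; within the scatter), so with the cyclopentyl in place, the chloro is not needed to keep the activity of compound 1 in this assay. Among the compounds shown here, this is the first reading on the ring that carries the trifluoromethyl group, and it contrasts with the only earlier step, an at least 19-fold higher number from compound 1 to compound 2 (1.29 log units; beyond the scatter), which showed that one change at the cyclopentyl place can be large while leaving open whether every place is as sensitive. Nothing measured here gives a reason why this step stays within the scatter.

From the compounds shown here alone, all three compounds keep the trifluoromethyl group, so it remains open what a nitrile or a methoxy group would do in its place, and whether a fluoro or a methyl at the chloro place would read like hydrogen. The cyclopentyl place is read only through cyclopentyl and phenyl, so a piperidine or a longer alkyl chain there is an open case, as is whether hydrogen in place of chloro reads the same with phenyl on that nitrogen.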